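The compounds below may be only part of what the source reports. "The series", "measured", "known", "first", "only" and "open" are said of these compounds alone.

Compound 1 `O=C(CSc1c[nH]c2cccc(Cl)c12)Nc1ccc(Cl)c(Cl)c1` was tested in an ADME assay on HEK-293T cells (Homo sapiens) for cytotoxicity, read by CCK-8 assay, with a stated time of 48 h (on this read-out higher numbers stand for lower toxicity in this test and lower numbers for higher toxicity in this test), where compound 1 gives 34700 nM. Compound 2 `COc1cccc2[nH]cc(SCC(=O)Nc3ccc(Cl)c(Cl)c3)c12` carries methoxy in place of chloro on an aromatic carbon. For compound 2 the read-out is a limit of the assay, > 100000 nM. This makes an at least 2.8-fold higher number from compound 1 to compound 2 (0.45 log units; beyond the scatter), known only as a bound because of the limit of > 100000 nM in this assay, at which 2 of the 3 values shown sit. Compound 3 `CCOc1ccccc1NC(=O)CSc1c[nH]c2cc(Cl)ccc12` rests on a different core; the difference between the two cores is not broken down here. For compound 3 the result is again a limit of the assay, > 100000 nM. Compound 4 `CCOc1ccccc1NC(=O)CSc1c[nH]c2cc(OC)ccc12` carries methoxy in place of chloro on an aromatic carbon. This is the same kind of change as in the earlier pair, but the place differs: here it is meta to a fused ring and para to a fused ring, whereas before it was ortho to a fused ring and meta to a fused ring. In this assay the expected step is a step that the limit leaves unreadable from compound 3 to compound 4, a small shift at most. That expectation rests on compound 3 already giving > 100000 nM, a limit of the assay. Compound 4 is therefore estimated at 150000 nM, most likely reported only as a limit again.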

Compound 4, half-maximal cytotoxic concentration: 88200 nM
The estimate for compound 4 lay 1.7-fold (0.23 log units) above the measured number, within the range that was stated.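

In this assay, methoxy in place of chloro gives an at least 1.1-fold lower number from compound 3 to compound 4 (0.05 log units; that floor lies within the scatter). Set beside the earlier pair, the same change does not carry over unchanged from one core to the other: the same change on two cores in this assay, an at least 2.8-fold higher number (0.45 log units; beyond the scatter) from compound 1 to compound 2 and an at least 1.1-fold lower number (0.05 log units; that floor lies within the scatter) from compound 3 to compound 4, at least 3.2-fold (0.51 log units) apart, beyond the scatter of two such steps

What this does not show is how large either step really is, or whether the place of the change or the rest of the molecule sets the two steps apart: the limit of > 100000 nM in this assay, at which 2 of the 4 values shown sit.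

The compounds shown leave open how chloro and methoxy would compare at both places on a single core. Also open, as far as these compounds go, is how an amine or a carboxylic acid on that same aromatic carbon would read in this assay.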